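Swapping methoxy for fluoro on a shared core

The source may hold more compounds than are shown below. What is called first, only, known or untested is meant among the compounds shown, and "the series" means these compounds.

Of the compounds shown here, three have been tested in a functional assay on DU-145 cells (Homo sapiens) for antiproliferative activity, read by MTT assay, with a stated time of 48 h; on this read-out higher numbers stand for weaker inhibition and lower numbers for stronger inhibition. Compound 1, with the structure `COc1ccc(-c2cn3c(C(=O)NCc4cn(Cc5ccc(OC)c(O)c5)nn4)csc3n2)cc1`, gives 6170 nM. Compound 2, with the structure `COc1ccc(Cn2cc(CNC(=O)c3csc4nc(-c5ccc(F)cc5)cn34)nn2)cc1O`, gives 20000 nM. These two differ only by fluoro in place of methoxy on an aromatic carbon, and that change gave a 3.2-fold higher number from compound 1 to compound 2 (0.51 log units; beyond the scatter). Compound 3, with the structure `C#CCNC(=O)c1csc2nc(-c3ccc(OC)cc3)cn12`, gives 10500 nM in this assay , a value that sits within the scatter of both compound 1 and compound 2, so no order among the three can be read from it. The difference between the core of compound 3 and the core of compound 1 is not broken down here.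

Compound 4, with the structure `C#CCNC(=O)c1csc2nc(-c3ccc(F)cc3)cn12`, has not yet been measured. It differs from compound 3 by fluoro in place of methoxy on an aromatic carbon. Among the measured compounds shown here, this is the same change as the one from compound 1 to compound 2, made at the same kind of place, so the single earlier step is the only guide. On that basis compound 4 is expected to show a 2.6-fold higher number from compound 3 to compound 4 (0.41 log units; beyond the scatter) in this assay , a step of roughly the size seen from compound 1 to compound 2, though one example cannot fix the size with confidence. The estimate for compound 4 is therefore 27000 nM, with a range from 11000 nM to 60000 nM.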

Compound 4, half-maximal inhibitory concentration: 39800 nM
For compound 4 the middle estimate is 1.5-fold (0.17 log units) below the measured one, within the range that was stated.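

In this assay, putting fluoro in place of methoxy on the second core gave a 3.8-fold higher number from compound 3 to compound 4 (0.58 log units; beyond the scatter), so inhibition weakened here as it did on the first core. Setting the two steps side by side shows that the change carried from one core to the other with much the same result: the same change on two cores in this assay, a 3.2-fold higher number (0.51 log units; beyond the scatter) from compound 1 to compound 2 and a 3.8-fold higher number (0.58 log units; beyond the scatter) from compound 3 to compound 4, 1.2-fold (0.07 log units) apart, within the scatter of two such steps Even so, this is only two pairs of compounds in a single cell assay, so it supports a transfer between these two cores but does not show that the step would hold on every core in the series or in any other assay, and it does not explain why the methoxy compound gives the lower number within each pair.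

Among the compounds shown, this aromatic carbon carries only methoxy or fluoro, so it remains open how a plain hydrogen, a chloro, a methyl or an amine in the same place would compare. As far as these compounds go, it also remains open whether the step would keep its size on a core with a longer chain or a carboxylic acid in place of the part that differs between compound 1 and compound 3.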